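A few compounds are considered here, and "the series" means these few. Any claim that something is new, unique, unknown or untested is made for them only; others in the source may bear on it.

Working notes on the series in a functional assay on A549 cells (Homo sapiens) for antiproliferative activity, read by MTT assay, with a stated time of 48 h; a lower number here means a stronger inhibitor, a higher number a weaker inhibitor. Compound 1 (`COc1cccc(-c2nn(-c3ccccc3)cc2C(Nc2nc3ccccc3s2)c2c(O)ccc3ccccc23)c1`) gives 24800 nM and compound 2 (`O=[N+]([O-])c1ccc(-c2nn(-c3ccccc3)cc2C(Nc2nc3ccccc3s2)c2c(O)ccc3ccccc23)cc1`) gives 41300 nM. Compound 2 therefore stands within the scatter of compound 1, and the two numbers set no order between them.

Compound 3 (`Cc1ccc2nc(NC(c3cn(-c4ccccc4)nc3-c3ccc([N+](=O)[O-])cc3)c3c(O)ccc4ccccc34)sc2c1`) keeps everything in compound 2 except one group: 1,3-benzothiazol-2-yl becomes 6-methyl-1,3-benzothiazol-2-yl, with methyl in place of hydrogen on an aromatic carbon.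

Among the compounds with values here, only one measured step is available, a 1.7-fold higher number from compound 1 to compound 2 (0.22 log units; within the scatter). It puts 4-nitrophenyl in place of 3-methoxyphenyl, so it concerns a different part of the molecule and bears on the new change only indirectly. It does show that one substituent swap in this series stayed within the scatter. Within the data shown here, no measured compound carries a substituent on the 1,3-benzothiazol-2-yl group, so the size of this methyl effect is not covered by the data.

No shift beyond the scatter is expected, and the estimated change is a 1.2-fold lower number from compound 2 to compound 3 (0.07 log units; within the scatter). Compound 3 is estimated at 35000 nM, with an expected range of 15000 nM to 75000 nM.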

Compound 3, half-maximal inhibitory concentration: 29000 nM
Estimate against measurement, compound 3: 1.2-fold (0.08 log units) above, and the stated range covers the measured number.
By their numbers in this assay, from the lowest: compounds 1, 3 and 2 (each within the scatter of the next).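

In this assay the step to 6-methyl-1,3-benzothiazol-2-yl reads a 1.4-fold lower number from compound 2 to compound 3 (0.15 log units; within the scatter) and gives the first measured substitution on the 1,3-benzothiazol-2-yl group, so methyl in place of hydrogen on this aromatic carbon does not separate the two compounds. The earlier step, a 1.7-fold higher number from compound 1 to compound 2 (0.22 log units; within the scatter), concerned the other end of the molecule, with 4-nitrophenyl in place of 3-methoxyphenyl, so a single change at each of two different places has now stayed within the scatter. Nothing at hand bears on why this methyl leaves the number within the scatter.

On these data alone, this reading rests on a single group at a single carbon of the benzothiazole, against the 4-nitrophenyl background of compound 2, so it is open whether the same methyl would also stay within the scatter on the 3-methoxyphenyl background of compound 1. Also open, as far as these compounds go, is whether an amine, a carboxylic acid or a longer chain such as butyl on the same aromatic carbon would give a step beyond the scatter.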